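This account rests on a few compounds, and the source may have more. Where it says the series, first, only, none or still open, it means among the compounds named here.

Compound 1 `CCn1c(C(=O)NCC(=O)OC)ccc1C(CC)(CC)c1ccc(OCS(=O)(=O)c2ccccc2)c(C)c1` carries a (methoxycarbonyl)methyl group on an amide-type nitrogen. In a functional assay on MCF7 cells (Homo sapiens) for antiproliferative activity, read by MTT assay, with a stated time of 24 h (a higher number here means a weaker inhibitor, a lower number a stronger inhibitor), compound 1 gives > 50000 nM, which is a limit rather than a number, so its true strength is not pinned down; this is the limit of > 50000 nM in this assay, at which 1 of the 3 values shown sits. Two neighbours have measured values: compound 2 `CCn1c(C(=O)N[C@H](CO)C(C)C)ccc1C(CC)(CC)c1ccc(OCS(=O)(=O)c2ccccc2)c(C)c1` gives 25500 nM in this assay, and compound 3 `CCn1c(C(=O)NC2(C(=O)O)CC2)ccc1C(CC)(CC)c1ccc(OCS(=O)(=O)c2ccccc2)c(C)c1` gives 41200 nM. The steps from compound 1 are an at least 1.9-fold lower number from compound 1 to compound 2 (0.29 log units; that floor lies within the scatter) and an at least 1.2-fold lower number from compound 1 to compound 3 (0.08 log units; that floor lies within the scatter), and between the two measured neighbours there is a 1.6-fold higher number from compound 2 to compound 3 (0.21 log units; within the scatter), so all three compounds behave much alike.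

Compound 4 `CCn1c(C(=O)N[C@@H](C(=O)O)C(C)C)ccc1C(CC)(CC)c1ccc(OCS(=O)(=O)c2ccccc2)c(C)c1` differs from compound 1 by 1-carboxy-2-methylpropyl in place of (methoxycarbonyl)methyl on an amide-type nitrogen. The entering group shares a carboxy part with the 1-carboxycyclopropyl of compound 3 and a 2-methylpropyl branch with the 1-(hydroxymethyl)-2-methylpropyl of compound 2, both of which gave weak inhibitors. A small downward step at most is therefore expected, an at least 1.3-fold lower number from compound 1 to compound 4 (0.11 log units; that floor lies within the scatter), with a real chance that only a limit is reported again. Compound 4 is estimated at 38000 nM, within 15000 nM to 90000 nM.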

Compound 4, half-maximal inhibitory concentration: 44700 nM
Estimate against measurement, compound 4: 1.2-fold (0.07 log units) below; the range from low to high includes it.
By their numbers in this assay, from the lowest: compounds 2, 3 and 4 (each within the scatter of the next). At a limit, above all of these: compound 1.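

In this assay, the change on this amide-type nitrogen gives an at least 1.1-fold lower number from compound 1 to compound 4 (0.04 log units; that floor lies within the scatter), and this can be read only as a floor, since the value for compound 1 is a limit: the limit of > 50000 nM in this assay, at which 1 of the 4 values shown sits.

The other two comparisons are a 1.1-fold higher number from compound 3 to compound 4 (0.04 log units; within the scatter) and a 1.8-fold higher number from compound 2 to compound 4 (0.24 log units; within the scatter), so replacing either 1-carboxycyclopropyl or 1-(hydroxymethyl)-2-methylpropyl with 1-carboxy-2-methylpropyl leaves the number within the scatter. Compounds 2, 3 and 4 therefore cannot be told apart here, even though they carry three different groups at this position.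

As far as these compounds go, it remains open whether an amine or a longer plain carbon chain on this nitrogen would move the number beyond the scatter. Also open, from the compounds shown here alone, is how the mirror-image form of the 1-carboxy-2-methylpropyl group would compare with compound 4.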